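A fluorine on the distal phenyl ring

This account rests on a few compounds, and the source may have more. Where it says the series, first, only, none or still open, it means among the compounds named here.

Measured so far:
compound 1, `O=C(CCc1cccc2c1B(O)OC2)Nc1ccccc1`: 350 nM
compound 2, `CC(C)c1cccc(NC(=O)CCc2cccc3c2B(O)OC3)c1`: 1600 nM
compound 3, `O=C(CCc1cccc2c1B(O)OC2)Nc1cccc(-c2ccccc2)c1`: 890 nM

In a functional assay on HCT-116 cells (Homo sapiens) for antiproliferative activity, read by MTT assay, with a stated time of 72 h (on this read-out higher numbers stand for weaker inhibition and lower numbers for stronger inhibition), compound 1 gives 350 nM, compound 2 gives 1600 nM and compound 3 gives 890 nM. Compound 3 stands second highest of the three numbers: a 1.8-fold lower number from compound 2 to compound 3 (0.25 log units; within the scatter), whereas a 2.5-fold higher number from compound 1 to compound 3 (0.41 log units; beyond the scatter). The other step, a 4.6-fold higher number from compound 1 to compound 2 (0.66 log units; beyond the scatter), also lies beyond the scatter.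

Compound 4, `O=C(CCc1cccc2c1B(O)OC2)Nc1cccc(-c2ccc(F)cc2)c1`, differs from compound 3 by fluoro in place of hydrogen on an aromatic carbon; read one bond further out, the phenyl of compound 3 becomes 4-fluorophenyl. Going by the values given here, none of the measured steps concerns a change on this outer ring; all three concern the anilide ring, and they are modest at most. Among the compounds with values here, the data therefore offer no step that bears directly on this change, and no shift beyond the scatter is expected in this assay. Compound 4 is estimated at 900 nM, with a range of 450 nM to 1800 nM, which means an expected step of a 1.0-fold higher number from compound 3 to compound 4 (0.00 log units; within the scatter).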

Compound 4, half-maximal inhibitory concentration: 550 nM
Compound 4: the middle estimate sits 1.6-fold (0.21 log units) above what was measured, and the stated range covers the measured number.
By their numbers in this assay, from the lowest: compounds 1, 4, 3 and 2 (each within the scatter of the next, the first and the last beyond it).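

In this assay, going by these compounds alone, the first change on the outer ring, fluoro in place of hydrogen para to a large group, cannot be told from the scatter (a 1.6-fold lower number from compound 3 to compound 4 (0.21 log units; within the scatter)). With 4-fluorophenyl in that place, the step from the isopropyl group lies beyond the scatter (a 2.9-fold lower number from compound 2 to compound 4 (0.46 log units; beyond the scatter)) and the step from hydrogen lies within it (a 1.6-fold higher number from compound 1 to compound 4 (0.20 log units; within the scatter)), whereas with plain phenyl these two readings fall the other way round. No accompanying measurement speaks to the reason for this, so the account rests on the values alone.

The compounds shown leave open whether a chloro, methoxy, amine or carboxylic acid group in the same place would behave as fluoro does. They also leave open what fluoro would do elsewhere on the outer ring.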